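The compounds below may be only part of what the source reports. "The series", "measured", "known", "first", "only" and "open" are said of these compounds alone.

Measured so far:
compound 1 `COc1ccc2nc(C)cc(NCc3ccc(F)c(F)c3)c2c1`: 12000 nM
compound 2 `COc1cccc(CNc2cc(C)nc3ccc(OC)cc23)c1`: 12500 nM

In a functional assay on MCF-10A cells (Homo sapiens) for antiproliferative activity, with a stated time of 48 h (a higher number here means that more compound is needed for the effect, a lower number that less compound is needed), compound 2 gives 12500 nM. It stands level with compound 1 at 12000 nM, as the two values lie within the scatter of each other.

The next compound is compound 3 `COc1ccc2nc(C)cc(NCc3ccc(F)c(OC)c3)c2c1`. It differs from compound 2 by fluoro in place of hydrogen on an aromatic carbon, with fluoro in place of hydrogen on an aromatic carbon, ortho to a methoxy group and para to a large group. Among the measured compounds shown here, no measured pair differs in one place, so no direct precedent exists for this change. No step beyond the scatter is expected in this assay, and no direction is favoured. The estimated step of a 1.1-fold lower number from compound 2 to compound 3 (0.06 log units; within the scatter) therefore stays small. The expected value for compound 3 is 11000 nM, with an estimated range of 5000 nM to 22000 nM.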

Compound 3, half-maximal effective concentration: 12900 nM
Compound 3: middle estimate off by 1.2-fold (0.07 log units), on the low side; measured number inside the range.
By their numbers in this assay, from the lowest: compounds 1, 2 and 3 (each within the scatter of the next).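

In this assay, fluoro in place of hydrogen on an aromatic carbon, ortho to a methoxy group and para to a large group, gives a 1.0-fold higher number from compound 2 to compound 3 (0.01 log units; within the scatter), so the number stays level with fluoro at this position. The second pair, methoxy in place of fluoro on an aromatic carbon, gives a 1.1-fold higher number from compound 1 to compound 3 (0.03 log units; within the scatter), so neither exchange separates the compounds, and these two single changes give the series its first direct readings. No supporting measurement bears on this result.

Still open, going by these compounds, is whether any group at this position moves the number beyond the scatter, for example an amine, a carboxylic acid or a longer chain such as butoxy. The compounds shown also leave open whether the level readings would hold with changes elsewhere on the shared core.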